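Cytotoxicity notes on an amide series: step to compound 4

The compounds below may be only part of what the source reports. "The series", "measured", "known", "first", "only" and "open" are said of these compounds alone.

Measured so far in an ADME assay on HepG2 2.2.15 cells (Homo sapiens) for cytotoxicity, read by MTT assay, with stated times of 48 h and 9 days; a lower number here means that less compound is tolerated, a higher number that more compound is tolerated:
compound 1, `O=C(/C=C/c1coc2cc(O)ccc2c1=O)NCc1ccccc1`: 436000 nM
compound 2, `COc1ccc2c(=O)c(/C=C/C(=O)NCc3cccc(F)c3)coc2c1`: 475000 nM
compound 3, `COc1ccc(NC(=O)/C=C/c2coc3cc(O)ccc3c2=O)cc1`: 976000 nM

Compound 2 holds the middle value of the three in this assay; its gap to compound 1 lies within the scatter, its gap to compound 3 beyond it. Going by the values given here, compound 1 and compound 2 differ in two places at once, so no single step links them; their two values simply sit close together.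

The next compound, compound 4, is `COc1ccc2c(=O)c(/C=C/C(=O)Nc3ccc(Cl)cc3)coc2c1`. Relative to compound 2 the change is 4-chlorophenyl in place of 3-fluorobenzyl on an amide-type nitrogen. Among the compounds with values here, one measured step bears on it: the swap from a benzyl to an aryl group on the same amide nitrogen, a 2.2-fold higher number from compound 1 to compound 3 (0.35 log units; beyond the scatter), a modest rise. The change to compound 4 is of the same kind, a benzyl giving way to a substituted phenyl, so a step of similar size and direction is expected in this assay: a 2.0-fold higher number from compound 2 to compound 4 (0.30 log units; within the scatter). Nothing measured here separates the effect of the chlorine from that of the ring swap itself, so the range is kept wide. For compound 4 the expected value is 950000 nM, between 500000 nM and 1800000 nM.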

Compound 4, half-maximal cytotoxic concentration: 272000 nM
Compound 4: middle estimate off by 3.5-fold (0.54 log units), on the high side, outside the stated range (below it).
By their numbers in this assay, from the lowest: compounds 4, 1 and 2 (each within the scatter of the next); then compound 3.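

In this assay, replacing 3-fluorobenzyl with 4-chlorophenyl on the amide-type nitrogen gives a 1.7-fold lower number from compound 2 to compound 4 (0.24 log units; within the scatter), so at this position the change does not move the number beyond the usual scatter. The earlier step of the same broad kind, a 2.2-fold higher number from compound 1 to compound 3 (0.35 log units; beyond the scatter), therefore does not carry over as a general rule: of the two benzyl-to-substituted-phenyl steps shown, one lies beyond the scatter and the other within it, and the two pairs also differ in the substituent on the core and in the groups on the amide-type nitrogen. Nothing available accounts for the difference between these two steps.

The compounds shown do not separate the contribution of the chlorine from that of replacing the benzyl with a phenyl, nor that of the fluorine from that of the benzyl itself. Also open, going by these compounds, is how the number in this assay would respond to an amine or a carboxylic acid on the aromatic ring, or to a longer chain between the amide-type nitrogen and that ring.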